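A few compounds are considered here, and "the series" means these few. Any claim that something is new, unique, unknown or untested is made for them only; others in the source may bear on it.

Measured so far:
Compound 1, `CNCc1cn(S(=O)(=O)c2ncccc2C)c(-c2cccnc2F)c1F`: 54%
Compound 2, `CNCc1cn(S(=O)(=O)c2cccc(F)n2)c(-c2cccnc2F)c1F`: "not determined" (no result reported)

Compound 1 carries a methyl-bearing pyridine ring on the sulfonyl sulfur, and in a functional assay on the whole organism (strain Jcl:Sprague-Dawley) for inhibition, with Rattus norvegicus as the target, with stated times of 3 min and 3 h, at a dose of 1 mg/kg by the intravenous route (on this read-out higher numbers stand for more inhibition at the one dose given (going by the name of the read-out) and lower numbers for less inhibition), compound 1 gives 54%. Compound 2 carries a 6-fluoropyridin-2-yl on that same sulfur, and for compound 2 the entry reads "not determined" (no result reported), so compound 2 stands nowhere on the scale shown; only compound 1 gives a fixed point.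

Compound 3, `CNCc1cn(S(=O)(=O)c2cncc(C)c2)c(-c2cccnc2F)c1F`, is the unmeasured member. Between compound 2 and compound 3 the change is 5-methylpyridin-3-yl in place of 6-fluoropyridin-2-yl on a sulfonyl sulfur. Among the measured compounds shown here, without a value for compound 2, no step can be measured from it; the only anchor is compound 1, which also carries a methylpyridine on the sulfonyl sulfur. On that ground compound 3 is expected to land in the same region as compound 1, with no step beyond the scatter foreseen, and the estimate for compound 3 in this assay is 48%, in the range 20% to 75%.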

Compound 3, a percentage reported as inhibition, in the whole organism at one dose (the size of the read-out at that dose, not a potency): 87%
For compound 3 the middle estimate is 39 percentage points below the measured one; the whole stated range lies below it.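

Two groups that are both methylpyridines on the sulfonyl sulfur need not behave alike in this assay: 5-methylpyridin-3-yl in place of 3-methylpyridin-2-yl gives a number 33 percentage points higher from compound 1 to compound 3 (beyond the scatter). The same atoms, arranged differently within this group, are therefore enough to change the result at this position, so the shared label "methylpyridine" was not a safe guide. The step from compound 2 to compound 3 cannot be read, and no measurement shown here explains the difference between compound 1 and compound 3.

From the compounds shown here alone, whether the methyl on the ring of compound 3 contributes to the result remains open; a methoxy group in its place, or a plain phenyl ring in place of the whole pyridine, would be informative. These figures also come from a single dose, so they give the size of inhibition at that dose and not a potency.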